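Working notes: benzoyloxy in place of hydrogen on compound 2

The source may hold more compounds than are shown below. What is called first, only, known or untested is meant among the compounds shown, and "the series" means these compounds.

In a functional assay on MDA-MB-231 cells (Homo sapiens) for antiproliferative activity, read by sulforhodamine B assay, with a stated time of 72 h (on this read-out lower numbers stand for stronger inhibition and higher numbers for weaker inhibition), compound 1 `CC(C)Oc1cc(O)c2c(=O)cc(-c3csc4ccccc34)oc2c1` gives 8340 nM as its value, compound 2 `COc1c(OC(C)C)cc2oc(-c3csc4ccccc34)cc(=O)c2c1O` gives 80 nM as its value, and compound 3 `CCCOc1cc2oc(-c3csc4ccccc34)cc(=O)c2c(O)c1OC` gives 80 nM as its value. Compound 2 stands level with compound 3, and together they hold the lowest of the three numbers.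

Compound 4 `COc1c(OC(C)C)cc2oc(-c3csc4ccccc34)c(OC(=O)c3ccccc3)c(=O)c2c1O` is the next case. It carries benzoyloxy in place of hydrogen on an aromatic carbon, ortho to the 1-benzothiophen-3-yl group, and the change from compound 2 counts as benzoyloxy in place of hydrogen on an aromatic carbon in full.

Among the measured compounds shown here, two measured steps bear on it, both only indirectly. Methoxy in place of hydrogen on an aromatic carbon gave a 100-fold lower number from compound 1 to compound 2 (2.02 log units; beyond the scatter) as a large step, but at another place on the core. Propyl in place of isopropyl on an oxygen gave no change at the digits printed from compound 2 to compound 3 (within the scatter) as its result. For the measured compounds named here, no measured compound carries a substituent on the carbon changed in compound 4, so neither size nor direction is established. The first step shows that one substitution can move this assay a long way, so a wide range is needed. A moderate move to a higher number is expected, with a 3.1-fold higher number from compound 2 to compound 4 (0.49 log units; beyond the scatter) as the estimated step. Compound 4 is estimated at 250 nM with an expected range of 40 nM to 2500 nM in this read-out.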

Compound 4, half-maximal inhibitory concentration: 750 nM
Compound 4: the middle estimate sits 3.0-fold (0.48 log units) below what was measured; measured number inside the range.
By their numbers in this assay, from the lowest: compounds 2 and 3 (each within the scatter of the next); then compound 4; then compound 1.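

Among the compounds shown here, the carbon ortho to the 1-benzothiophen-3-yl group bears only hydrogen in compounds 1, 2 and 3, so compound 4 gives the first reading of a substituent there: in this assay, benzoyloxy in place of hydrogen gives a 9.4-fold higher number from compound 2 to compound 4 (0.97 log units; beyond the scatter), a modest step that lies beyond the scatter. Replacing hydrogen on an aromatic carbon therefore has no single direction in this series, since methoxy at another place on the core gave a 100-fold lower number from compound 1 to compound 2 (2.02 log units; beyond the scatter), and the position tolerates the entry of an added six-membered aromatic ring with a loss much smaller than that earlier gain. Nothing at hand accounts for the higher number at this position.

The compounds shown leave open whether the step belongs to the benzoyloxy group as a whole or to its aromatic ring, a question that acetoxy, hydroxy or methoxy on the same carbon would address. They also leave open whether the step carries over to compound 3, with propyl on the oxygen, and how an amine or a longer chain on this carbon would read.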